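Swapping oxolan-3-yl for cyclobutyl: an expected gain

The source may report more compounds than this note shows. Statements on the series, on what has been measured and on what is new or still open speak of the compounds shown alone.

compound 1 `CCn1c(-c2ccccc2)nc2c(NC3CCC3)ncnc21`: 84 nM
compound 2 `Cn1c(-c2ccccc2)nc2c(NC3CCOC3)ncnc21`: 6260 nM

In an assay on CHO cells for displacement of a labelled ligand from adenosine receptor A3 (Homo sapiens), read by scintillation counting, with a stated time of 3 h (on this read-out lower numbers stand for stronger inhibition and higher numbers for weaker inhibition), compound 2 gives the higher of the two numbers, and compound 1 sits far below it, a gap beyond the usual scatter. Compound 3 `Cn1c(-c2ccccc2)nc2c(NC3CCC3)ncnc21` differs from compound 2 by cyclobutyl in place of oxolan-3-yl on a nitrogen on an aromatic ring. Compound 1 carries the same cyclobutyl but also differs from compound 2 in a second place, so no single-change comparison is available. Still, the cyclobutyl of compound 1 goes with the low number, so a large drop in this assay is expected, a 21-fold lower number from compound 2 to compound 3 (1.32 log units; beyond the scatter). Compound 3 is estimated at 300 nM, within a range of 80 nM to 1500 nM.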

Compound 3, inhibition constant: 280 nM
The estimate for compound 3 lay 1.1-fold (0.03 log units) above the measured number; the measured number falls inside the stated range.
By their numbers in this assay, from the lowest: compound 1; then compound 3; then compound 2.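

In this assay, going by these compounds alone, cyclobutyl in place of oxolan-3-yl on a nitrogen on an aromatic ring gives a 22-fold lower number from compound 2 to compound 3 (1.35 log units; beyond the scatter), the first single-change reading at this position. The second place also counts, but less: hydrogen in place of methyl on a saturated chain carbon bound to an aromatic nitrogen gives a 3.3-fold higher number from compound 1 to compound 3 (0.52 log units; beyond the scatter) in this comparison. Nothing measured here accounts for either step.

The compounds shown leave open whether cyclopentyl or an open propyl chain on that nitrogen would match cyclobutyl. They also leave open how a longer chain at the second place would read.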